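Dropping the acyl group from compound 2

The source may hold more compounds than are shown below. What is called first, only, known or untested is meant among the compounds shown, and "the series" means these compounds.

For the measured compounds named here, in a functional assay on KYSE-450 cells (Homo sapiens) for inhibition, read by MTT assay, with a stated time of 48 h (on this read-out lower numbers stand for stronger inhibition and higher numbers for weaker inhibition), compound 2 `C/C=C/C(=O)N(Cc1ccc(OC)c(N)c1)c1cc(OC)c(OC)c(OC)c1` gives 310 nM, the lowest of the three numbers so far. Compound 3 `C/C=C/C(=O)N(Cc1ccc(OC)c(Cl)c1)c1cc(OC)c(OC)c(OC)c1` gives 10100 nM, and compound 1 `COc1ccc(CNc2cc(OC)c(OC)c(OC)c2)cc1[N+](=O)[O-]` gives 16800 nM.

The unmeasured compound 4 `COc1ccc(CNc2cc(OC)c(OC)c(OC)c2)cc1N` differs from compound 2 as follows: hydrogen in place of (prop-1-en-1-yl)carbonyl on a nitrogen on an aromatic ring. Hydrogen takes the place of (prop-1-en-1-yl)carbonyl on a nitrogen on an aromatic ring.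

Going by the values given here, no measured step covers this change. Among the compounds with values here, the only step available, a 33-fold higher number from compound 2 to compound 3 (1.51 log units; beyond the scatter), is chloro in place of amino on an aromatic carbon, a different change. It bears only indirectly, showing that one replacement in this series can produce a large step. Compound 1 also lacks the (prop-1-en-1-yl)carbonyl group and gives 16800 nM, but it carries no amino group, so it is only a loose guide. A higher number than that of compound 2 in this assay is expected, with a step beyond the scatter, though its size is poorly constrained.

The expected step is a 9.7-fold higher number from compound 2 to compound 4 (0.99 log units; beyond the scatter). For compound 4 the estimated value is 3000 nM. The expected range runs from 600 nM to 15000 nM.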

Compound 4, half-maximal inhibitory concentration: 2210 nM
Estimate against measurement, compound 4: 1.4-fold (0.13 log units) above; low and high end bracket the measured number.
By their numbers in this assay, from the lowest: compound 2; then compound 4; then compounds 3 and 1 (each within the scatter of the next).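

In this assay, the (prop-1-en-1-yl)carbonyl group on the nitrogen is not essential for a measurable effect, yet removing it costs potency: hydrogen in its place gives the modest step (a 7.1-fold higher number from compound 2 to compound 4 (0.85 log units; beyond the scatter)). The amino group also counts without the acyl group, since amino in place of nitro gives a step of similar size (a 7.6-fold lower number from compound 1 to compound 4 (0.88 log units; beyond the scatter)). Compound 4 thus adds a second amino comparison to the large step seen with chloro in the acylated pair, although the replaced groups differ.

An acetyl or butanoyl group on that nitrogen would show whether the step follows from the double bond of the (prop-1-en-1-yl)carbonyl group or from acylation in general. Nothing available explains either step.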